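The source may hold more compounds than are shown below. What is called first, only, known or untested is meant among the compounds shown, and "the series" means these compounds.

Values so far in a functional assay on MCF7 cells (Homo sapiens) for antiproliferative activity, read by CellTiter-Glo, with a stated time of 5 days (a higher number here means a weaker inhibitor, a lower number a stronger inhibitor), are:

compound 1 `CC/C(=C(/c1ccc(/C=C/C(=O)O)cc1)c1ccc(-c2cc[nH]n2)cc1)c1ccccc1` gives 440 nM
compound 2 `CC/C(=C(/c1ccc(/C=C/C(=O)O)cc1)c1ccc(-n2ccnc2)cc1)c1ccccc1` gives 380 nM
compound 3 `CC/C(=C(/c1ccc(/C=C/C(=O)O)cc1)c1ccc(N2CCCCC2)cc1)c1ccccc1` gives 450 nM
compound 4 `CC/C(=C(/c1ccc(/C=C/C(=O)O)cc1)c1ccc(N2CCN(C)CC2)cc1)c1ccccc1` is not yet measured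

Compound 3 stands at (450 nM) and cannot be told apart from the other two compounds, as both of its steps lie within the scatter (a 1.0-fold higher number from compound 1 to compound 3 (0.01 log units; within the scatter)) and (a 1.2-fold higher number from compound 2 to compound 3 (0.07 log units; within the scatter)). The remaining step is also within the scatter (a 1.2-fold lower number from compound 1 to compound 2 (0.06 log units; within the scatter)). Compound 4 replaces the group of compound 3 with 4-methylpiperazin-1-yl in place of piperidin-1-yl on an aromatic carbon, para to a large group (4-methylpiperazin-1-yl in place of piperidin-1-yl on an aromatic carbon). All three measured steps change the group at this place, so they bear directly on the new change. None of the three measured compounds carries 4-methylpiperazin-1-yl, so this expectation is an extrapolation. In the short-named readout (this assay) no shift beyond the scatter is expected, and the estimated step is small (no change at the digits printed from compound 3 to compound 4 (within the scatter)). The estimated value for compound 4 is (450 nM), with an expected range from (200 nM) to (1000 nM).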

Compound 4, half-maximal inhibitory concentration: 220 nM
Compound 4: middle estimate off by 2.0-fold (0.31 log units), on the high side, within the range that was stated.
By their numbers in this assay, from the lowest: compounds 4, 2, 1 and 3 (each within the scatter of the next, the first and the last beyond it).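

Among the compounds shown here, at this place, on an aromatic carbon para to a large group, 4-methylpiperazin-1-yl in place of piperidin-1-yl gives the first step beyond the scatter in this assay (a 2.0-fold lower number from compound 3 to compound 4 (0.31 log units; beyond the scatter)), so the position is not wholly indifferent to the group it carries. The separation is modest and rests on this one pair, as 4-methylpiperazin-1-yl in place of 1H-imidazol-1-yl (a 1.7-fold lower number from compound 2 to compound 4 (0.24 log units; within the scatter)) and in place of 1H-pyrazol-3-yl (a 2.0-fold lower number from compound 1 to compound 4 (0.30 log units; within the scatter)) both stay within the scatter. No measurement at hand explains the step.

Still open, from the compounds shown here alone, is whether the step follows the added ring nitrogen or the methyl on it, which piperazin-1-yl and morpholin-4-yl at the same place would help to separate. Also open, going by these compounds, is whether it persists with a methyl ester in place of the carboxylic acid.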